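The source may hold more compounds than are shown below. What is called first, only, known or untested is meant among the compounds shown, and "the series" means these compounds.

In a functional assay (aorta) with Rattus norvegicus as the target (a lower number here means that less compound is needed, a higher number that more compound is needed for the effect), compound 3 (`COc1ccc(-c2nc(CNC(=O)C3=NNC(=O)CC3)sc2-c2ccc(OC)cc2)cc1`) gives 7.3 uM and lies within the scatter of compound 2 (`COc1ccc(-c2nc(CNC(=O)CSC)sc2-c2ccc(OC)cc2)cc1`), which gives 6 uM there. For compound 1 (`COc1ccc(-c2nc(/N=C(\N)NC3CCCCC3)sc2-c2ccc(OC)cc2)cc1`) the reading of > 100 uM is a limit of the assay, not a number. Compound 4 (`CNC(=O)NCc1nc(-c2ccc(OC)cc2)c(-c2ccc(OC)cc2)s1`) departs from compound 3 by a group of 2 heavy atoms (1 carbon, 1 nitrogen; no ring) in place of a group of 7 heavy atoms (4 carbon, 2 nitrogen, 1 oxygen; one six-membered non-aromatic ring with 2 hetero atoms), on a carbonyl carbon with methylamino as the entering group. The step of a 1.2-fold higher number from compound 2 to compound 3 (0.09 log units; within the scatter) also exchanges a group on a carbonyl carbon and stays within the scatter. The large step of an at least 16-fold lower number from compound 1 to compound 2 (1.22 log units; beyond the scatter) concerns a group on an aromatic carbon and so bears less on this change. No step beyond the scatter is therefore expected in this assay here. The expected step is a 1.1-fold higher number from compound 3 to compound 4 (0.04 log units; within the scatter) and no larger. Compound 4 is expected at 8 uM with 2.5 uM to 30 uM as the estimated range.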

Compound 4, concentration for half-maximal effect: 15 uM
Compound 4: the middle estimate sits 1.9-fold (0.27 log units) below what was measured; measured number inside the range.
By their numbers in this assay, from the lowest: compounds 2 and 3 (each within the scatter of the next); then compound 4. At a limit, above all of these: compound 1.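

In this assay the exchange on the carbonyl carbon now registers: a 2.1-fold higher number from compound 3 to compound 4 (0.31 log units; beyond the scatter) and a 2.5-fold higher number from compound 2 to compound 4 (0.40 log units; beyond the scatter) are both modest steps beyond the scatter, so methylamino does not match the two groups it replaces, which could not be told apart from each other. Even so, an at least 6.6-fold lower number from compound 1 to compound 4 (0.82 log units; beyond the scatter) still holds for the compound carrying methylamino. That step rests on a limit for compound 1, not on a number: the limit of > 100 uM in this assay, at which 1 of the 4 values shown sits. The compounds shown leave open whether ethylamino, a longer chain, or a carboxylic acid on this carbonyl carbon would stay with compound 2 and compound 3 or move further from them.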